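The source may hold more compounds than are shown below. What is called first, only, known or untested is meant among the compounds shown, and "the series" means these compounds.

Working notes on the series. In a functional assay on MCF7 cells (Homo sapiens) for antiproliferative activity, read by sulforhodamine B assay, with a stated time of 72 h (a lower number here means a stronger inhibitor, a higher number a weaker inhibitor), compound 1 (`FC(F)(F)c1ccc(/C=C\c2cc3ccccc3nc2Cl)c(C(F)(F)F)c1`) gives 10500 nM. From the compounds shown here alone, compound 2 (`COc1ccc2nc(Cl)c(/C=C\c3ccc(C(F)(F)F)cc3C(F)(F)F)cc2c1`) gives > 50000 nM, which is a limit of the assay and not a number, so its true position is unknown. Compound 3 (`COc1ccc2nc(Cl)c(/C=C\c3ccccc3C(F)(F)F)cc2c1`) keeps the methoxy of compound 2 and differs from it by hydrogen in place of trifluoromethyl on an aromatic carbon, with hydrogen in place of trifluoromethyl on an aromatic carbon. For the measured compounds named here, no measured step covers this change. Going by the values given here, the only measured step is a different one, methoxy in place of hydrogen on an aromatic carbon. Taking an at least 4.7-fold higher number from compound 1 to compound 2 (0.67 log units; beyond the scatter) as the only guide to size, a modest move towards a lower number in this assay is expected, estimated as an at least 2.5-fold lower number from compound 2 to compound 3 (0.39 log units; beyond the scatter). A second reading at the limit remains possible. For compound 3 the expected value is 20000 nM, with an estimated range of 5000 nM to 50000 nM.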

Compound 3, half-maximal inhibitory concentration: 4470 nM
Beside the measured number, compound 3's estimate is 4.5-fold (0.65 log units) above it; measured number below the stated range.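

With the methoxy kept, hydrogen in place of trifluoromethyl on this aromatic carbon, para to a large group and meta to a trifluoromethyl group, gives an at least 11-fold lower number from compound 2 to compound 3 (1.04 log units; beyond the scatter) in this assay. A trifluoromethyl group at this carbon is therefore not needed for a measurable value, and the methoxy does not by itself put a compound at the limit. The true size of the step stays unknown, as its starting point for compound 2 is a limit of the assay and not a number: the limit of > 50000 nM in this assay, at which 1 of the 3 values shown sits.

The compounds shown leave open whether the same replacement would have a similar effect on the core of compound 1, without the methoxy. They also leave open how a fluorine atom, a methyl group or an amine would compare with hydrogen at this carbon.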